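A few compounds are considered here, and "the series" means these few. Any claim that something is new, unique, unknown or untested is made for them only; others in the source may bear on it.

Measured in a functional assay on the whole organism (Tail, strain ICR) with Mus musculus as the target, in the tail flick test, with a stated time of 30 min, at a dose of 25 umol/kg by the oral route; on this read-out higher numbers stand for a stronger effect at the one dose given and lower numbers for a weaker effect:
compound 1 `CC(C)[C@H](NC(=O)CN(c1nc(Cl)nc2[nH]cnc12)C1CC1)C(=O)OCc1ccccc1` gives 33.4%
compound 2 `CC(C)(C)OC(=O)NCCCC[C@H](NC(=O)CN(c1ncnc2c1ncn2C1CCCCO1)C1CC1)C(=O)OCc1ccccc1` gives 18.3%
compound 3 `CC(C)[C@H](NC(=O)CN(c1nc(Cl)nc2[nH]cnc12)C1CC1)C(=O)O` gives 31.2%

Compound 1 stands at the highest of the three numbers. Its nearest neighbour is compound 3, and the step of a number 2.2 percentage points lower from compound 1 to compound 3 (within the scatter) lies within the scatter. Compound 2 sits beyond the scatter below compound 1, but it differs from compound 1 in more than one place, so only its value itself is of use here.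

Compound 4 `NC(=O)C[C@H](NC(=O)CN(c1nc(Cl)nc2[nH]cnc12)C1CC1)C(=O)OCc1ccccc1` has not yet been measured in this assay. It differs from compound 1 as follows: carbamoylmethyl in place of isopropyl on a saturated chain carbon bound to an amide-type nitrogen and a carbonyl carbon. For the measured compounds named here, the only measured single step, a number 2.2 percentage points lower from compound 1 to compound 3 (within the scatter), concerns the ester end and does not touch this position, so nothing measured bears directly on the change. With no guidance from the shown steps, a modest loss or no change beyond the scatter is expected. Compound 4 is therefore estimated at 25%, with a range from 10% to 40%, an expected step of a number 8.4 percentage points lower from compound 1 to compound 4 (within the scatter).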

Compound 4, a percentage reported as activity, at one dose (the size of the read-out at that dose, not a potency): 24.4%
The estimate for compound 4 lay 0.6 percentage points above the measured number; the measured number falls inside the stated range.
By their numbers in this assay, from the lowest: compounds 2, 4, 3 and 1 (each within the scatter of the next, the first and the last beyond it).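

In this assay, the saturated chain carbon bound to an amide-type nitrogen and a carbonyl carbon now has a measured step of its own: a number 9 percentage points lower from compound 1 to compound 4 (within the scatter) for carbamoylmethyl in place of isopropyl. At this place, then, a group carrying a hydrogen-bond donor and a hydrogen-bond acceptor stays within the scatter of the isopropyl compound. No evidence at hand accounts for this result.

Still open, on these data alone, is how an amine, a carboxylic acid or a longer chain would read at this place. Also open, as far as these compounds go, is whether carbamoylmethyl would behave the same with a free carboxylic acid in place of the benzyl ester.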